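Swapping phenylcarbamoyl for (4-chlorophenyl)sulfonyl: stability outlook

The source may report more compounds than this note shows. Statements on the series, on what has been measured and on what is new or still open speak of the compounds shown alone.

Measured compounds:
compound 1, `COc1cc(-c2c(C)nc3c(N4CC[C@@H](NC(C)=O)C4)cc(C)nn23)cc(OC)c1OC`, gives a limit of > 95%.
compound 2, `CC(=O)N[C@@H]1CCN(c2cc(C)nn3c(-c4cccc(S(=O)(=O)N(C)C)c4)c(C)nc23)C1`, gives a limit of > 95%.
compound 3, `COc1ccc(-c2c(C)nc3c(N4CC[C@@H](NC(=O)Nc5ccccc5)C4)cc(C)nn23)cc1OC`, gives a limit of > 95%.

All three readings come from an ADME assay on microsomes from liver (Mus musculus) for metabolic stability, read by LC-MS, with NADPH named in the record, with a stated time of 60 min, tested at 1 uM, in the absence of a further agent; a higher number here means that more of the compound is left, a lower number that less of the compound is left. Each of these values is a limit of the assay, not a number, so the three compounds cannot be told apart on this read-out. Compound 3 therefore stands at the limit in this assay, together with the other two: the limit of > 95% in this assay, at which 3 of the 3 values shown sit. Among the compounds with values here, no pair of measured compounds differs in only one place, so no measured step is available to lean on.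

Compound 4, `COc1ccc(-c2c(C)nc3c(N4CC[C@@H](NS(=O)(=O)c5ccc(Cl)cc5)C4)cc(C)nn23)cc1OC`, is not yet measured in this assay. It differs from compound 3 in one place: (4-chlorophenyl)sulfonyl in place of phenylcarbamoyl on an amine nitrogen. The change sits on the amine nitrogen whose other neighbour is a saturated ring carbon.

With compound 3 at the limit and nothing measured for the incoming group, the step from compound 3 to compound 4 is expected to be a number at least 5 percentage points lower from compound 3 to compound 4 (that floor lies within the scatter), a step no larger than the scatter and, if anything, downward. Compound 4 is thus expected to give about 90% in this assay, within a range of 70% to 98%, with a fair chance that the assay again reports only a limit.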

Compound 4, percent of the compound remaining: > 95%
Compound 4 gave a limit, no number; the forecaster's own chance of this, stated with the estimate: 55%; middle value at least 5 percentage points away from the limit.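

In this assay compound 4 gives > 95%, a limit and not a number. Compound 3 also stands at a limit, so no step can be read between compound 3 and compound 4: the limit of > 95% in this assay, at which 4 of the 4 values shown sit.

The compounds shown leave open how the four compare in stability, and whether (4-chlorophenyl)sulfonyl in place of phenylcarbamoyl changes it at all.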